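Dihydrochalcone series: one methyl removal, carried to compound 4

The source may hold more compounds than are shown below. What is called first, only, known or untested is meant among the compounds shown, and "the series" means these compounds.

Compound 1 `COc1ccc(CCC(=O)c2ccc(O)cc2)c(OC)c1`, compound 2 `COc1ccc(C(=O)CCc2c(OC)cc(O)cc2OC)cc1` and compound 3 `COc1ccc(CCC(=O)c2ccc(O)cc2)c(O)c1` have been measured in a functional assay on A549 cells (Homo sapiens) for cytotoxicity, read by MTT assay, with a stated time of 72 h; on this read-out higher numbers stand for weaker inhibition and lower numbers for stronger inhibition; compound 4 `COc1cc(O)cc(OC)c1CCC(=O)c1ccc(O)cc1` has not. In this assay compound 1 gives 89500 nM and compound 3 gives 12000 nM. Compound 2 gives only a limit of the assay in this assay, > 100000 nM, as stated by the limit of > 100000 nM in this assay, at which 1 of the 3 values shown sits. How the core of compound 2 differs from that of compound 1 is not broken down here.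

Among the measured compounds shown here, the one measured step is a 7.5-fold lower number from compound 1 to compound 3 (0.87 log units; beyond the scatter), made by hydrogen in place of methyl on an oxygen on an aromatic ring. The same change, (hydrogen in place of methyl on an oxygen on an aromatic ring), takes compound 2 to compound 4; the two places read the same, so it is the same change made on a different core, and it occurs twice among the compounds shown.

For the measured compounds named here, only the one measured step supports an expectation, and the starting point is a limit, so the number behind compound 2 may lie anywhere past it. The expected step from compound 2 to compound 4 in this assay is an at least 2.0-fold lower number from compound 2 to compound 4 (0.30 log units; that floor lies within the scatter), resting on the measured step of compound 1 to compound 3, a 7.5-fold lower number from compound 1 to compound 3 (0.87 log units; beyond the scatter), read against the limit of compound 2. Compound 4 is therefore estimated at 50000 nM in this assay, with a range from 12000 nM to 200000 nM, and a fair chance that the assay again reports only a limit.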

Compound 4, half-maximal inhibitory concentration: 42900 nM
Compound 4: middle estimate off by 1.2-fold (0.07 log units), on the high side; low and high end bracket the measured number.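

In this assay, methoxy to hydroxy on the core of compound 2 again goes with a lower number, an at least 2.3-fold lower number from compound 2 to compound 4 (0.36 log units; beyond the scatter), so the direction seen on the core of compound 1 holds on a second core. The value of compound 2 is a limit of the assay, > 100000 nM, and not a number. The true size of the step on this core therefore stays unknown, and the pair gives no ground for saying that the change is worth the same amount on both cores: the same change on two cores in this assay, a 7.5-fold lower number (0.87 log units; beyond the scatter) from compound 1 to compound 3 and an at least 2.3-fold lower number (0.36 log units; beyond the scatter) from compound 2 to compound 4; the limit leaves it open whether they differ

The pattern rests on two pairs on two cores, and the compounds shown exchange only methyl for hydrogen on an oxygen on an aromatic ring, so they leave open whether the direction holds on any further core. They also leave open what a longer chain on that oxygen, such as ethyl or propyl, would do in this assay, and what an amine or a carboxylic acid in place of the hydroxy group would do.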